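The source may report more compounds than this note shows. Statements on the series, on what has been measured and on what is new or still open speak of the compounds shown alone.

Measured so far in a functional assay on HL-60 cells (Homo sapiens) for inhibition, read by MTT assay, with a stated time of 72 h; a higher number here means a weaker inhibitor, a lower number a stronger inhibitor:
compound 1 `Cc1nc(-c2ccc(F)cc2)c(C(=O)N2CCN(c3cccc(Cl)c3)CC2)o1`: 40.1 nM
compound 2 `Cc1ccc(C)c(N2CCN(C(=O)c3oc(C)nc3-c3cccc(Cl)c3)CC2)c1`: 345 nM
compound 3 `Cc1ccc(N2CCN(C(=O)c3oc(C)nc3-c3ccccc3)CC2)c(C)c1`: 101 nM

Compound 3 stands second highest of the three numbers in this assay. Its nearest neighbour is compound 1, which sits at a lower number, and that gap lies beyond the scatter. Compound 2 is furthest from compound 3, at a higher number, again beyond the scatter. Compound 2 and compound 3 each differ from compound 1 at two places, so no single structural change can be tied to any of these gaps.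

Compound 4 `Cc1nc(-c2ccccc2)c(C(=O)N2CCN(c3ccc(Cl)c(Cl)c3)CC2)o1` has not yet been measured in this assay. Against compound 3 the change is 3,4-dichlorophenyl in place of 2,4-dimethylphenyl on an amine nitrogen in a ring. Going by the values given here, no pair of measured compounds differs in one place only, so no step of this kind has been observed. The two compounds carrying a dimethyl-substituted ring on the amine nitrogen in a ring, compound 2 and compound 3, give the two higher numbers, while compound 1 gives the lowest, but that reading rests on compounds that also differ elsewhere. A moderate step toward a lower number is expected, a 1.7-fold lower number from compound 3 to compound 4 (0.23 log units; within the scatter), with a real chance it remains within the scatter. For compound 4 the estimate in this assay is 60 nM, with a range from 25 nM to 150 nM.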

Compound 4, half-maximal inhibitory concentration: 124 nM
Beside the measured number, compound 4's estimate is 2.1-fold (0.32 log units) below it; the range from low to high includes it.
By their numbers in this assay, from the lowest: compound 1; then compounds 3 and 4 (each within the scatter of the next); then compound 2.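

In this assay, going by these compounds alone, the first step that differs in one place only, 3,4-dichlorophenyl in place of 2,4-dimethylphenyl on an amine nitrogen in a ring, gives a 1.2-fold higher number from compound 3 to compound 4 (0.09 log units; within the scatter). At this position, the exchange replaces both methyl groups with chlorine and moves the substitution pattern on the ring, yet leaves the heavy-atom count unchanged and adds no hydrogen-bond donors or acceptors, and the two compounds cannot be separated in this assay. This step gives no support to the idea that the dimethyl-substituted ring accounts for the higher numbers, and nothing available explains why the two groups read alike.

On these data alone, whether this position stays as insensitive with a different kind of group on the nitrogen, such as a pyridine ring, a phenyl ring carrying a carboxylic acid, or a longer chain ending in an amine, remains open. Also open, as far as these compounds go, is what sets compound 1 at 40.1 nM apart, as it differs from compound 3 at two places and its gap cannot be tied to either one alone.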